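A few compounds are considered here, and "the series" means these few. Any claim that something is new, unique, unknown or untested is made for them only; others in the source may bear on it.

Measured compounds in the series:

compound 1, `Cc1nn(-c2nc(-c3ccc(Cl)c(Cl)c3)c(SC(C)C)s2)c(C(=O)O)c1-c1ccccc1`: 3000 nM
compound 2, `COc1ccc(C)cc1-c1c(C)nn(-c2nc(-c3ccc(Cl)c(Cl)c3)c(SC(C)C)s2)c1C(=O)O`: 9500 nM
compound 3, `Cc1nn(-c2nc(-c3ccc(Cl)c(Cl)c3)c(SC(C)C)s2)c(C(=O)O)c1-c1cc(C#N)cc(C(F)(F)F)c1`: 3600 nM

All three share one core and differ only in the aryl group on the five-membered ring. In a functional assay on BJAB cells (Homo sapiens) for antiproliferative activity, with a stated time of 4 days (a lower number here means that less compound is needed, a higher number that more compound is needed for the effect), compound 1 gives the lowest number of the three. Its nearest neighbour is compound 3, with a step of a 1.2-fold higher number from compound 1 to compound 3 (0.08 log units; within the scatter), which is within the scatter, so no order between compound 1 and compound 3 can be read from these two values. Compound 2 sits furthest, with a step of a 3.2-fold higher number from compound 1 to compound 2 (0.50 log units; beyond the scatter). Between the two substituted aryl groups the step runs a 2.6-fold lower number from compound 2 to compound 3 (0.42 log units; beyond the scatter).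

The next compound, compound 4, `Cc1cc(-c2c(C)nn(-c3nc(-c4ccc(Cl)c(Cl)c4)c(SC(C)C)s3)c2C(=O)O)cc(C)n1`, has not yet been measured. It differs from compound 1 by 2,6-dimethylpyridin-4-yl in place of phenyl on an aromatic carbon.

Among the compounds with values here, two measured steps bear on this change, both replacing the same phenyl. The substituted phenyl of compound 3 left the number unchanged within the scatter, while the substituted phenyl of compound 2 gave a modest rise. The new group in compound 4 carries two methyl groups and a ring nitrogen, a pattern not covered by either earlier step, so the expectation in this assay is a step from compound 1 of a 1.5-fold higher number from compound 1 to compound 4 (0.18 log units; within the scatter), at most a modest rise, possibly none beyond the scatter. Compound 4 is therefore expected to give about 4500 nM, within a range of 1500 nM to 13000 nM.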

Compound 4, half-maximal effective concentration: 580 nM
Compound 4: middle estimate off by 7.8-fold (0.89 log units), on the high side, and the stated range ends above it.
By their numbers in this assay, from the lowest: compound 4; then compounds 1 and 3 (each within the scatter of the next); then compound 2.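

Within the data shown here, at the aromatic carbon next to the ring atom that bears a carboxy group, 2,6-dimethylpyridin-4-yl gives the only step down from compound 1 in this assay, with a 5.2-fold lower number from compound 1 to compound 4 (0.71 log units; beyond the scatter), so this position can lower the number as well as leave it unchanged or raise it. The other two aryl groups compare the same way, with a 6.2-fold lower number from compound 3 to compound 4 (0.79 log units; beyond the scatter) and a 16-fold lower number from compound 2 to compound 4 (1.21 log units; beyond the scatter), which places compound 4 lowest of the four, beyond the scatter from each. The change brings in a ring nitrogen and two methyl groups together, so these steps cannot divide the drop between them, and nothing measured here explains it.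

Still open, as far as these compounds go, is how the ring nitrogen and the methyl groups each contribute, which plain pyridin-4-yl and 3,5-dimethylphenyl at this position would separate. Also open, from the compounds shown here alone, is whether the number of compound 4 holds with a primary amide in place of the carboxy group, or with an ethyl group in place of the methyl group on the five-membered ring.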